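Swapping the aromatic group on compound 3

The source may hold more compounds than are shown below. What is called first, only, known or untested is meant among the compounds shown, and "the series" means these compounds.

- compound 1 `CC1=CC[C@@H]([C@@](C)(O)CCCC(C)(C)NC=S)CC1`: 42500 nM
- compound 2 `CC1=CC[C@@H]([C@@](C)(O)CCCC(C)(C)NC(=S)NN)CC1`: > 100000 nM, a limit of the assay
- compound 3 `COc1ccc(/C=N\NC(=S)NC(C)(C)CCC[C@](C)(O)[C@@H]2CC=C(C)CC2)cc1`: 22100 nM

In a functional assay on UACC-62 cells (Homo sapiens) for cytotoxicity, read by sulforhodamine B assay (on this read-out lower numbers stand for stronger inhibition of growth and higher numbers for weaker inhibition of growth), compound 3 at 22100 nM and compound 1 at 42500 nM lie within the scatter of each other. Compound 4 `CC1=CC[C@@H]([C@@](C)(O)CCCC(C)(C)NC(=S)N/N=C\c2cccc([N+](=O)[O-])c2)CC1` differs from compound 3 as follows: 3-nitrophenyl in place of 4-methoxyphenyl on a carbon with a double bond to nitrogen. That is, 3-nitrophenyl replaces 4-methoxyphenyl on a carbon with a double bond to nitrogen. For the measured compounds named here, no measured step exchanges one aromatic group for another. The closest are an at least 4.5-fold lower number from compound 2 to compound 3 (0.65 log units; beyond the scatter), which brings in the aromatic group, and, less directly, an at least 2.3-fold higher number from compound 1 to compound 2 (0.37 log units; beyond the scatter). Neither gives a direction for this exchange, so no shift beyond the scatter is expected. The expected change is a 1.1-fold higher number from compound 3 to compound 4 (0.04 log units; within the scatter). Compound 4 is estimated at 24000 nM, with an expected range of 10000 nM to 60000 nM.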

Compound 4, concentration for total growth inhibition: 24700 nM
Estimate against measurement, compound 4: 1.0-fold (0.01 log units) below, and the stated range covers the measured number.
By their numbers in this assay, from the lowest: compounds 3, 4 and 1 (each within the scatter of the next). At a limit, above all of these: compound 2.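

In this assay, exchanging one aromatic group for another on a carbon with a double bond to nitrogen gives a 1.1-fold higher number from compound 3 to compound 4 (0.05 log units; within the scatter). This place therefore accepts both 4-methoxyphenyl and 3-nitrophenyl without a change beyond the scatter, although the two groups differ in their atoms and in their count of hydrogen-bond acceptors. Nothing shown gives a cause for this result.

From the compounds shown here alone, whether a phenyl ring carrying an amine or a carboxylic acid would also stay within the scatter remains open. So does the effect of a longer chain at this place.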